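Aryl Amide Swap on the Hexafluoro-Carbinol Naphthalene Series

A few compounds are considered here, and "the series" means these few. Any claim that something is new, unique, unknown or untested is made for them only; others in the source may bear on it.

Three amides sharing one core have been measured in an assay on LtK cells with ATP-sensitive inward rectifier potassium channel 11 (Homo sapiens) as the target; on this read-out lower numbers stand for an effect already at smaller amounts and higher numbers for an effect only at larger amounts of compound. Compound 1 `CCC(=O)Nc1c(C(O)(C(F)(F)F)C(F)(F)F)ccc2ccccc12` gives 15 nM. Compound 2 `O=C(Nc1c(C(O)(C(F)(F)F)C(F)(F)F)ccc2ccccc12)C1CCCC1` gives 495 nM, and compound 3 `O=C(CCc1ccccc1)Nc1c(C(O)(C(F)(F)F)C(F)(F)F)ccc2ccccc12` gives 1750 nM. Compound 3 thus stands highest of the three numbers: the step of a 3.5-fold higher number from compound 2 to compound 3 (0.55 log units; beyond the scatter) is modest, while the step of a 120-fold higher number from compound 1 to compound 3 (2.07 log units; beyond the scatter) is large, as is the step of a 33-fold higher number from compound 1 to compound 2 (1.52 log units; beyond the scatter).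

Compound 4 `Cc1ccccc1C(=O)Nc1c(C(O)(C(F)(F)F)C(F)(F)F)ccc2ccccc12` has not yet been measured. It differs from compound 3 in one place: 2-methylphenyl in place of phenethyl on a carbonyl carbon. The measured steps all concern what sits on the carbonyl carbon, and each enlargement from ethyl raised the number, yet none of them involves a 2-methylphenyl group, so the direction for compound 4 is not fixed by the data. Given that the step of a 3.5-fold higher number from compound 2 to compound 3 (0.55 log units; beyond the scatter) was only modest, compound 4 is expected to land near compound 3, with the estimated step being a 1.9-fold lower number from compound 3 to compound 4 (0.29 log units; within the scatter). For compound 4 the estimate in this assay is 900 nM, with a range from 150 nM to 5000 nM.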

Compound 4, half-maximal effective concentration: 5550 nM
For compound 4 the middle estimate is 6.2-fold (0.79 log units) below the measured one, and the stated range ends below it.
By their numbers in this assay, from the lowest: compound 1; then compound 2; then compound 3; then compound 4.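

In this assay, a ring set directly on the carbonyl carbon does not bring the number back towards that of the ethyl amide: a 3.2-fold higher number from compound 3 to compound 4 (0.50 log units; beyond the scatter) places 2-methylphenyl above phenethyl, although phenethyl is the larger group by heavy-atom count. Compound 4 therefore goes against the order by size that held for ethyl, cyclopentyl and phenethyl, and it now has the highest number of the four, with an 11-fold higher number from compound 2 to compound 4 (1.05 log units; beyond the scatter) and a 370-fold higher number from compound 1 to compound 4 (2.57 log units; beyond the scatter) both large. Nothing available explains why these groups fall in this order.

The compounds shown leave open whether a plain phenyl without the methyl would differ from 2-methylphenyl. They also leave open whether a methyl group, or a short chain carrying an amine, on the carbonyl carbon would match or go below ethyl.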